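This account rests on a few compounds, and the source may have more. Where it says the series, first, only, none or still open, it means among the compounds named here.

Three compounds built on a tetrabrominated bicyclic core carrying a nitrile-tipped chain on the ring nitrogen have been tested in a functional assay on CCRF-CEM cells (Homo sapiens) for cytotoxicity, read by MTT assay, with a stated time of 24 h, tested at 50 uM; on this read-out higher numbers stand for a weaker effect at the one concentration tested and lower numbers for a stronger effect. Compound 1 `Cc1nc2c(Br)c(Br)c(Br)c(Br)c2n1CC#N` gives 2%, compound 2 `N#CCCn1cnc2c(Br)c(Br)c(Br)c(Br)c21` gives 2%, and compound 3 `Cc1nc2c(Br)c(Br)c(Br)c(Br)c2n1CCCC#N` gives 1%. Compound 2 and compound 1 are built from the same atoms joined differently; the difference between the two cores is not broken down here. From compound 1 to compound 3 the chain is lengthened, (2-cyanoethyl in place of cyano on a saturated chain carbon bound to an aromatic nitrogen), and this step changed the read-out in this assay by a number 1 percentage points lower from compound 1 to compound 3 (within the scatter).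

Compound 4 `N#CCCCCn1cnc2c(Br)c(Br)c(Br)c(Br)c21` is not yet measured. It stands to compound 2 as compound 3 stands to compound 1, through (2-cyanoethyl in place of cyano on a saturated chain carbon, two bonds along the chain from an aromatic nitrogen). The two changes are of the same kind rather than the same: in compound 1 the change sits on a saturated chain carbon bound to an aromatic nitrogen, in compound 2 on a saturated chain carbon two bonds along the chain from an aromatic nitrogen. Because the earlier lengthening gave a number 1 percentage points lower from compound 1 to compound 3 (within the scatter), the step from compound 2 to compound 4 is expected to be about no change at the digits printed from compound 2 to compound 4 (within the scatter) in this assay. Compound 4 is therefore estimated at 2%, most likely between 0% and 12%.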

Compound 4, a percentage reported as activity, at one concentration (the size of the read-out at that concentration, not a potency): 1%
Beside the measured number, compound 4's estimate is 1 percentage points above it; the measured number falls inside the stated range.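

In this assay, lengthening the chain on the core of compound 2 gives a number 1 percentage points lower from compound 2 to compound 4 (within the scatter), and setting this beside the same kind of change on the other core shows how the two compare: the same change on two cores in this assay, a number 1 percentage points lower (within the scatter) from compound 1 to compound 3 and a number 1 percentage points lower (within the scatter) from compound 2 to compound 4, 0 percentage points apart, within the scatter of two such steps

On these two pairs, then, the change carries from one core to the other with the same outcome: the read-out does not move beyond the usual scatter on either core. This does not show that chain length is irrelevant to cytotoxicity in general, since each number comes from a single concentration and is not a potency, and steps this small give no ranking of the chains or the cores.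

Still open, going by these compounds, is whether a longer chain, or a chain ending in an amine or a carboxylic acid instead of the nitrile, would leave the read-out where it stands. Also open, on these data alone, is whether these compounds would separate from one another at lower concentrations.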